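This account rests on a few compounds, and the source may have more. Where it says the series, first, only, none or still open, it means among the compounds named here.

Three compounds have been measured so far in a functional assay on A549 cells (Homo sapiens) for cytotoxicity, read by MTT assay, with a stated time of 72 h (on this read-out higher numbers stand for weaker inhibition and lower numbers for stronger inhibition), and their values are these
Compound 1 `S=C=NCCCCSCc1ccccc1` gives 51300 nM
Compound 2 `[O-][S+](CCCN=C=S)Cc1ccccc1` gives 11800 nM
Compound 3 `CC(C)[S+]([O-])CCCN=C=S` gives 16700 nM

Compound 2 stands at 11800 nM in this set and lies within the scatter of compound 3 at 16700 nM on the same read-out. Compound 1 at 51300 nM sits higher, beyond the scatter from compound 2.

Compound 4 `[O-][S+](CCCCCCN=C=S)Cc1ccccc1` has not yet been measured. It differs from compound 2 in one place, and the change is this: a group of 6 heavy atoms (4 carbon, 1 nitrogen, 1 sulfur; no ring) in place of a group of 3 heavy atoms (1 carbon, 1 nitrogen, 1 sulfur; no ring), on a saturated chain carbon, three bonds along the chain from a sulfur on a saturated chain carbon, three bonds along the chain from a sulfur.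

Among the compounds with values here, no two measured compounds differ in one place alone, so the data offer no direct step to lean on. In this assay a small move toward a lower number is expected, of a size within or close to the scatter. The estimated change is a 1.5-fold lower number from compound 2 to compound 4 (0.17 log units; within the scatter) and it is expected to stay modest. In this assay compound 4 is expected at 8000 nM with an estimated range from 3500 nM up to 18000 nM as the span of likely results.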

Compound 4, half-maximal inhibitory concentration: 14700 nM
Estimate against measurement, compound 4: 1.8-fold (0.26 log units) below, and the stated range covers the measured number.
By their numbers in this assay, from the lowest: compounds 2, 4 and 3 (each within the scatter of the next); then compound 1.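

Within the data shown here, this gives the first direct step in the set: in this assay, putting a group of 6 heavy atoms (4 carbon, 1 nitrogen, 1 sulfur; no ring) in place of a group of 3 heavy atoms (1 carbon, 1 nitrogen, 1 sulfur; no ring), on a saturated chain carbon, three bonds along the chain from a sulfur, gives a 1.2-fold higher number from compound 2 to compound 4 (0.10 log units; within the scatter) on this read-out. Among these compounds, at this position, then, the larger group leaves the cytotoxicity read-out where the smaller one put it, so the change can be made without a measurable cost or gain in this one cell assay, a point that the earlier compounds, none of which differed from another in one place alone, could not settle. Nothing measured alongside these values speaks to why the two compounds read alike.

The compounds shown leave open whether a longer chain at this position would still read the same, since a single step cannot show a trend across chain sizes. They also leave open what an amine or a carboxylic acid would do in place of this group on the same core.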